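Sulfonamide to amide swap in the dimethylcarboxamide series

A few compounds are considered here, and "the series" means these few. Any claim that something is new, unique, unknown or untested is made for them only; others in the source may bear on it.

Two members of the series have been measured in a functional assay on NCI-H1299 cells (Homo sapiens) for inhibition, read by CCK-8 assay, with a stated time of 72 h, tested at 1 uM; on this read-out lower numbers stand for a weaker effect and higher numbers for a stronger effect at the one concentration tested. Compound 1 `CN(C)C(=O)c1cc2cnc(Nc3ccc(S(=O)(=O)NCCCN=C=S)cc3)nc2n1C1CCCC1` gives 41.3%. Compound 2 `CN(C)C(=O)c1cc2cnc(Nc3ccc(S(=O)(=O)NCCCCCCN=C=S)cc3)nc2n1C1CCCC1` gives 42.4%. Among the compounds with values here, the only measured step, a number 1.1 percentage points higher from compound 1 to compound 2 (within the scatter), is a lengthening of the saturated chain and changes nothing beyond the scatter; compound 1 and compound 2 sit within the scatter of each other.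

Compound 3 `CN(C)C(=O)c1cc2cnc(Nc3ccc(C(=O)NCCCCN=C=S)cc3)nc2n1C1CCCC1` differs from compound 1 by a group of 10 heavy atoms (6 carbon, 2 nitrogen, 1 oxygen, 1 sulfur; no ring) in place of a group of 10 heavy atoms (4 carbon, 2 nitrogen, 2 oxygen, 2 sulfur; no ring), on an aromatic carbon, para to a large group. Within the data shown here, no measured pair tests a change of this kind; the chain lengthening from compound 1 to compound 2 bears on it only loosely, and that step was within the scatter. With no shown step to build on, the working assumption is a number near compound 1 and wide bounds. Compound 3 is expected to give about 41%, within 24% to 58%. The step of a number 0.3 percentage points lower from compound 1 to compound 3 (within the scatter) is expected to stay within the scatter.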

Compound 3, a percentage reported as inhibition, at one concentration (the size of the read-out at that concentration, not a potency): 55.2%
Compound 3: the middle estimate sits 14.2 percentage points below what was measured; measured number inside the range.
By their numbers in this assay, from the lowest: compounds 1 and 2 (each within the scatter of the next); then compound 3.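

Within the data shown here, on the aromatic carbon para to a large group, the exchange of the sulfonamide-bearing side chain for the amide-bearing one gives the first change in this assay that exceeds the scatter: a number 13.9 percentage points higher from compound 1 to compound 3 (beyond the scatter) is the modest step, whereas the sulfonamide chain lengthening gave only a number 1.1 percentage points higher from compound 1 to compound 2 (within the scatter) and so showed no response. The leaving and entering groups hold the same count of heavy atoms, but they differ both in the amide carbonyl replacing the sulfonyl and in chain length, so this step cannot assign the gain to either difference. No measurement available here accounts for the gain.

Still open, on these data alone, is how an amide with the shorter chain of compound 1 or with a longer chain would read out. Also open, as far as these compounds go, is whether the isothiocyanate end is needed, a question that an amine or an acrylamide at the chain end would address.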